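The compounds below may be only part of what the source reports. "The series", "measured", "known", "first", "only" and "open" are said of these compounds alone.

In a functional assay on COLO 205 cells (Homo sapiens) for inhibition, read by MTT assay, with a stated time of 48 h (on this read-out lower numbers stand for stronger inhibition and higher numbers for weaker inhibition), compound 1 (`COc1cc(OC)c(OC)cc1/C=C/C(=O)c1cc(OC)c(OC)c(OC)c1`) gives 18600 nM, compound 2 (`COc1cc(C(=O)/C=C/c2ccc(O)cc2)cc(OC)c1OC`) gives 29700 nM and compound 3 (`COc1cc(C(=O)/C=C/c2ccc(F)cc2)cc(OC)c1OC`) gives 25700 nM. Compound 3 therefore stands within the scatter of both other compounds, and the three values form a single band. Compound 4 (`COc1cc(C(=O)/C=C/c2ccc(C=O)cc2)cc(OC)c1OC`) carries the change (formyl in place of fluoro on an aromatic carbon), which is formyl in place of fluoro on an aromatic carbon, para to a large group. Among the compounds with values here, the only measured step at this place is a 1.2-fold lower number from compound 2 to compound 3 (0.06 log units; within the scatter), with fluoro in place of hydroxy, and it lies within the scatter. Within the data shown here, no measured compound carries formyl, so the data give no size for this change. No step beyond the scatter is expected in this assay, in either direction. The estimated step is a 1.3-fold lower number from compound 3 to compound 4 (0.11 log units; within the scatter). For compound 4 the expected value is 20000 nM, with an estimated range of 8000 nM to 42000 nM.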

Compound 4, half-maximal inhibitory concentration: 68800 nM
Beside the measured number, compound 4's estimate is 3.4-fold (0.54 log units) below it; the whole stated range lies below it.
By their numbers in this assay, from the lowest: compounds 1, 3 and 2 (each within the scatter of the next); then compound 4.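

Formyl gives a 2.7-fold higher number from compound 3 to compound 4 (0.43 log units; beyond the scatter) and a 2.3-fold higher number from compound 2 to compound 4 (0.36 log units; beyond the scatter) in this assay and so shifts the read-out modestly towards weaker inhibition. This position is therefore not indifferent to its substituent, although fluoro and hydroxy could not be told apart there. On these data alone, whether an amine, a carboxylic acid or a nitrile at the same place would also weaken inhibition stays open. Also open, as far as these compounds go, is what sets formyl apart from fluoro and hydroxy, and no measured evidence bears on that question.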